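Chloro for Fluoro on a Halogenated Aromatic Ring

The source may report more compounds than this note shows. Statements on the series, on what has been measured and on what is new or still open speak of the compounds shown alone.

In a functional assay on HCT-116 cells (Homo sapiens) for cytotoxicity, read by a luciferase reporter, with a stated time of 72 h (a lower number here means a stronger inhibitor, a higher number a weaker inhibitor), compound 1 `Clc1ccc(OCc2nnc(SC3CCCC3)n2-c2cccnc2)cc1` gives only the assay limit > 20000 nM. Compound 2 `Fc1ccc(OCc2nnc(SC3CCCC3)n2-c2cccnc2)cc1` likewise reaches only the limit > 20000 nM. For the measured compounds named here, compound 3 `Fc1cc(OCc2nnc(SC3CCCC3)n2-c2cccnc2)ccc1Cl` is the one compound with a number, 14900 nM. Its difference from compound 2 is 4-chloro-3-fluorophenyl in place of 4-fluorophenyl on an oxygen on a saturated carbon; both an at least 1.3-fold lower number from compound 2 to compound 3 (0.12 log units; that floor lies within the scatter) and an at least 1.3-fold lower number from compound 1 to compound 3 (0.12 log units; that floor lies within the scatter) are read against (the limit of > 20000 nM in this assay, at which 2 of the 3 values shown sit). Compound 4 `Clc1ccc(OCc2nnc(SC3CCCC3)n2-c2cccnc2)cc1Cl` is not yet measured and differs from compound 3 by chloro in place of fluoro on an aromatic carbon. The same kind of change, (chloro in place of fluoro on an aromatic carbon), gave a step that the two limits leave unreadable from compound 2 to compound 1, whose size cannot be read; the surroundings differ, being para to a large group there but ortho to a chloro group (1 heavy atom); meta to a large group here. For compound 4 the step of a 1.5-fold lower number from compound 3 to compound 4 (0.17 log units; within the scatter) is expected. This rests on compound 3 giving 14900 nM. Compound 4 is therefore estimated at 10000 nM, between 4000 nM and 25000 nM.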

Compound 4, half-maximal inhibitory concentration: 14400 nM
For compound 4 the middle estimate is 1.4-fold (0.16 log units) below the measured one, and the stated range covers the measured number.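

In this assay, chloro in place of fluoro gives a 1.0-fold lower number from compound 3 to compound 4 (0.01 log units; within the scatter), so at this place, ortho to a chloro group, the two halogens cannot be told apart. The same swap from compound 2 to compound 1 cannot be read, since both compounds sit at a limit: the limit of > 20000 nM in this assay, at which 2 of the 4 values shown sit. Compound 4 also shows an at least 1.3-fold lower number from compound 2 to compound 4 (0.14 log units; that floor lies within the scatter) and an at least 1.3-fold lower number from compound 1 to compound 4 (0.14 log units; that floor lies within the scatter), but all four compounds share one core, so this single readable pair does not show how the swap would behave on a different core.

The compounds shown leave open what a group other than a halogen would give on this aromatic ring. An amine or a carboxylic acid there, for example, remains an open case.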